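The source may hold more compounds than are shown below. What is called first, only, known or untested is meant among the compounds shown, and "the series" means these compounds.

In a functional assay on HepG2 cells (Homo sapiens) for cytotoxicity, read by MTT assay, with a stated time of 48 h (a lower number here means a stronger inhibitor, a higher number a weaker inhibitor), compound 1 (`CC(C)c1ccc(/C=C2/S/C(=N/c3ccccc3)N(Cc3ccncc3)C2=O)cc1`) gives 32300 nM, compound 2 (`COc1ccc(/C=C2/S/C(=N/c3ccccc3)N(Cc3ccncc3)C2=O)cc1OC`) gives 28900 nM and compound 3 (`O=C1/C(=C\c2cccc(Cl)c2)S/C(=N/c2ccccc2)N1Cc1ccncc1`) gives 28900 nM. These compounds differ only in the group on a double-bonded chain carbon bound to a double-bonded ring carbon. Compound 3 stands level with compound 2, and all three values lie within the scatter of one another.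

Compound 4 (`O=C1/C(=C\c2ccccn2)S/C(=N/c2ccccc2)N1Cc1ccncc1`) has pyridin-2-yl in place of 3-chlorophenyl at that same place: pyridin-2-yl in place of 3-chlorophenyl on a double-bonded chain carbon bound to a double-bonded ring carbon. All three measured steps at this place bear on the change: a 1.1-fold lower number from compound 1 to compound 2 (0.05 log units; within the scatter), a 1.1-fold lower number from compound 1 to compound 3 (0.05 log units; within the scatter) and no change at the digits printed from compound 2 to compound 3 (within the scatter). Each stays within the scatter. For the measured compounds named here, none of the measured compounds has a ring with a hetero atom at this place, so the data do not test that feature directly, and the range is kept wide. No step beyond the scatter is expected in this assay. The expected step is a 1.0-fold higher number from compound 3 to compound 4 (0.02 log units; within the scatter). Compound 4 is estimated at 30000 nM, with an expected range of 15000 nM to 60000 nM.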

Compound 4, half-maximal inhibitory concentration: 31000 nM
Compound 4: the middle estimate sits 1.0-fold (0.01 log units) below what was measured, and the stated range covers the measured number.
By their numbers in this assay, from the lowest: compounds 2, 3, 4 and 1 (each within the scatter of the next).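

In this assay a ring with a hetero atom at this place gives a 1.1-fold higher number from compound 3 to compound 4 (0.03 log units; within the scatter) alongside a 1.1-fold higher number from compound 2 to compound 4 (0.03 log units; within the scatter) and a 1.0-fold lower number from compound 1 to compound 4 (0.02 log units; within the scatter) and so pyridin-2-yl, with its one hydrogen-bond acceptor, reads no differently from the carbon-only aromatic rings. For the compounds shown here, the feature the earlier compounds left untested therefore separates compound 4 from none of them, and all four sit within the scatter of one another on the double-bonded chain carbon. Nothing at hand bears on why this position responds so little.

Still open, as far as these compounds go, is whether a non-aromatic group at this place, such as an amine, a carboxylic acid or a longer chain, would move the number beyond the scatter. Also open, from the compounds shown here alone, is whether a nitrile or trifluoromethyl group elsewhere on the shared core would do so.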